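Amine substituent changes in the series: compound 3 to compound 4

The compounds below may be only part of what the source reports. "The series", "measured", "known", "first", "only" and "open" are said of these compounds alone.

Measured in a functional assay on SK-BR-3 cells (Homo sapiens) for antiproliferative activity; on this read-out lower numbers stand for stronger inhibition and higher numbers for weaker inhibition:
- compound 1 `CC(C)=CCc1cc(C(=O)Nc2cc3ccc(OCCCNC(C)C)c(C)c3oc2=O)ccc1O`: 750 nM
- compound 2 `CC(C)=CCc1cc(C(=O)Nc2cc3ccc(OCCCNC(C)(C)C)c(C)c3oc2=O)ccc1O`: 660 nM
- compound 3 `CC(C)=CCc1cc(C(=O)Nc2cc3ccc(OCCCNC4CCCCC4)c(C)c3oc2=O)ccc1O`: 660 nM

Compound 3 stands level with compound 2, and all three values lie within the scatter of each other. Compound 4 `CC(C)=CCc1cc(C(=O)Nc2cc3ccc(OCCCN(C)C4CCCCC4)c(C)c3oc2=O)ccc1O` differs from compound 3 by methyl in place of hydrogen on an amine nitrogen. The nearest evidence is the set of measured changes around that nitrogen: a 1.1-fold lower number from compound 1 to compound 2 (0.06 log units; within the scatter), a 1.1-fold lower number from compound 1 to compound 3 (0.06 log units; within the scatter) and no change at the digits printed from compound 2 to compound 3 (within the scatter). For the measured compounds named here, no measured compound carries this methyl, so the evidence is indirect. The step expected in this assay is a 1.1-fold higher number from compound 3 to compound 4 (0.03 log units; within the scatter), with no firm direction and none expected beyond the scatter. For compound 4 the estimated value is 700 nM, with an expected range of 300 nM to 1600 nM.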

Compound 4, half-maximal inhibitory concentration: 970 nM
Beside the measured number, compound 4's estimate is 1.4-fold (0.14 log units) below it, and the stated range covers the measured number.
By their numbers in this assay, from the lowest: compounds 2, 3, 1 and 4 (each within the scatter of the next).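

Methyl on the amine nitrogen gives a 1.5-fold higher number from compound 3 to compound 4 (0.17 log units; within the scatter) in this assay and the wider swaps of the amine group give a 1.5-fold higher number from compound 2 to compound 4 (0.17 log units; within the scatter) and a 1.3-fold higher number from compound 1 to compound 4 (0.11 log units; within the scatter) with every step inside the scatter. For the compounds shown here, the earlier compounds all keep hydrogen on this nitrogen, so compound 4 is the first sign that methyl can stand there without a step beyond the scatter. No other data here bear on this result. On these data alone, whether methyl behaves the same on the nitrogen carrying isopropyl or tert-butyl stays open, as does a ring amine such as piperidine or morpholine at this place.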